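A few compounds are considered here, and "the series" means these few. Any claim that something is new, unique, unknown or untested is made for them only; others in the source may bear on it.

Of the compounds shown here, two have been measured in a functional assay on SK-N-SH cells (Homo sapiens) for inhibition; on this read-out higher numbers stand for weaker inhibition of growth and lower numbers for stronger inhibition of growth. Compound 1 `O=c1c2cc([N+](=O)[O-])cnc2sn1-c1ccc(Br)cc1` gives 53500 nM. Compound 2 `O=c1c2cccnc2sn1-c1ccccc1` gives 11200 nM, the lower of the two numbers, and its gap to compound 1 lies beyond the scatter. Compound 3 `CCCCc1ccc(-n2sc3ncccc3c2=O)cc1` has not yet been measured; it differs from compound 2 by butyl in place of hydrogen on an aromatic carbon. Within the data shown here, no measured pair shows this change, so the expected step of a 1.4-fold lower number from compound 2 to compound 3 (0.15 log units; within the scatter) is small, with no clear direction beyond the scatter. For compound 3 the estimate in this assay is 8000 nM, with a range from 2500 nM to 30000 nM.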

Compound 3, concentration for 50% growth inhibition: 8930 nM
The estimate for compound 3 lay 1.1-fold (0.05 log units) below the measured number, and the stated range covers the measured number.
By their numbers in this assay, from the lowest: compounds 3 and 2 (each within the scatter of the next); then compound 1.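

In this assay butyl in place of hydrogen on an aromatic carbon, para to a large group, gives a 1.3-fold lower number from compound 2 to compound 3 (0.10 log units; within the scatter) and so leaves the two numbers within the scatter. Among these compounds, this is the first reading at this position, and it shows that a butyl chain can sit there without moving the number beyond the scatter. Nothing at hand offers an explanation for this result.

Open, on these data alone, is whether an amine, a carboxylic acid or a longer chain at the same place would give a number beyond the scatter. Also open, as far as these compounds go, is whether butyl would act alike on the core of compound 1.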